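Trifluoromethyl for Methoxy on the Benzamide of Compound 2

The compounds below may be only part of what the source reports. "The series", "measured", "known", "first", "only" and "open" are said of these compounds alone.

compound 1: `Cc1ccc(C(=O)Nc2nc3cc(C)cc(C)c3s2)cc1` — 0.44 ug/mL
compound 2: `COc1ccc(C(=O)Nc2nc3c(OC)cccc3s2)cc1` — 1.25 ug/mL
compound 3: `COc1ccccc1NC(=O)Nc1nc2ccc(F)cc2s1` — > 10 ug/mL, a limit

In a functional assay on MDA-MB-231 cells (Homo sapiens) for antiproliferative activity, read by sulforhodamine B assay (a lower number here means a stronger inhibitor of growth, a higher number a weaker inhibitor of growth), compound 1 gives 0.44 ug/mL and compound 2 gives 1.25 ug/mL. For compound 3 the assay reports only a limit, > 10 ug/mL, and no number. Of the two numbers available, compound 2 stands highest; its nearest neighbour is compound 1, whose number is lower by a margin beyond the usual scatter. Compound 4, `COc1cccc2sc(NC(=O)c3ccc(C(F)(F)F)cc3)nc12`, has not yet been measured in this assay. It differs from compound 2 by trifluoromethyl in place of methoxy on an aromatic carbon. Among the measured compounds shown here, no measured pair shows this same change, so the expectation rests on the two numbers and on the change alone. A modest step is expected, in the direction of a lower number, at the edge of the scatter rather than clearly beyond it. The expected step is a 1.4-fold lower number from compound 2 to compound 4 (0.14 log units; within the scatter). Compound 4 is therefore expected, in this assay, to give about 0.9 ug/mL, with a range from 0.3 ug/mL to 3 ug/mL.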

Compound 4, concentration for 50% growth inhibition: > 10 ug/mL
Compound 4 was reported as a limit; the forecaster's own chance of this, stated with the estimate: 10%; at least 11-fold (1.04 log units) between middle value and limit.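

In this assay, trifluoromethyl in place of methoxy on this aromatic carbon, para to a large group, brings an at least 8.0-fold higher number from compound 2 to compound 4 (0.90 log units; beyond the scatter). Among the compounds shown here, this is the first pair that differs in one place, and it shows that growth inhibition here depends strongly on the group at this position, which the earlier compounds could not show. Compound 4 carries only a limit, > 10 ug/mL, and not a number, so the step has no upper bound and its printed size is set by that limit: the limit of > 10 ug/mL in this assay, at which 2 of the 4 values shown sit.

The compounds shown leave open how an amine, a hydroxyl or a carboxylic acid at this place would read, and whether any of them would give a lower number than methoxy. They also leave open whether the same change has a similar effect on another core, such as that of compound 1.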